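A Methyl Added to a Non-Toxic Sulfonamide

A few compounds are considered here, and "the series" means these few. Any claim that something is new, unique, unknown or untested is made for them only; others in the source may bear on it.

compound 1, `O=c1[nH]cc(S(=O)(=O)Nc2ccccc2-c2cn(-c3ccccc3Cl)nn2)c(=O)[nH]1`: 20800 nM
compound 2, `O=c1[nH]cc(S(=O)(=O)Nc2ccc(-c3cn(-c4ccccc4)nn3)cc2)c(=O)[nH]1`: "not toxic" (no number reported)

In an ADME assay on GES1 cells (Homo sapiens) for cytotoxicity, read by MTT assay, with a stated time of 24 h (a lower number here means that less compound is tolerated, a higher number that more compound is tolerated), compound 1 gives 20800 nM, whereas compound 2 gives "not toxic" (no number reported), for which no single number exists. On the numbers shown, compound 2 therefore stands without a value that could be placed next to compound 1, and no step between the two can be stated. Compound 3, `Cc1ccc(-n2cc(-c3ccc(NS(=O)(=O)c4c[nH]c(=O)[nH]c4=O)cc3)nn2)cc1`, differs from compound 2 by methyl in place of hydrogen on an aromatic carbon — methyl in place of hydrogen on an aromatic carbon. For the measured compounds named here, no step between measured compounds is recorded, so the expected size of this change rests only on how small the entering group is. Such an addition is expected to move this assay by no more than the scatter, in no clear direction. Compound 3 is therefore expected to show 50000 nM, with a range from 15000 nM to 160000 nM, and it may well again return only a limit rather than a number.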

Compound 3, half-maximal cytotoxic concentration: "not toxic" (no number reported)
For compound 3 the study gives words and no number; no gap can be computed for the estimate.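

In this assay, for the compounds shown here, compound 2 gives "not toxic" (no number reported) and compound 3 gives "not toxic" (no number reported) so no step between them can be read. The compounds shown leave open whether phenyl to 4-methylphenyl changes how much compound the cells tolerate. No other data shown bear on this result.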